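The compounds below may be only part of what the source reports. "The series", "measured", "known", "first", "only" and "open" are said of these compounds alone.

Working notes on the series, read in a physicochemical assay for lipophilicity, read by HPLC, at pH 7.5; a higher number here means a more lipophilic compound, a lower number a more polar compound. Compound 1 (`CCOc1ccccc1-c1ccc(-c2nc3cnccc3c(C[C@H](C)C(=O)O)c2C#N)cc1`) gives 2.2, compound 2 (`CCCCC(Nc1c(C#N)c(-c2ccc(-c3ccccc3OCC)cc2)nc2cnccc12)C(N)=O`) gives 3.6 and compound 3 (`CCOc1ccccc1-c1ccc(-c2nc3cnccc3c(N[C@H](CC)C(=O)O)c2C#N)cc1`) gives 2.1. Compound 3 thus stands level with compound 1, as a number 0.10 log units lower from compound 1 to compound 3 (within the scatter) shows, and well under compound 2.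

Next to be read in this assay is compound 4 (`CCOc1ccccc1-c1ccc(-c2nc3cnccc3c(NC(COC)C(N)=O)c2C#N)cc1`). The change is 1-carbamoyl-2-methoxyethyl in place of 1-carboxypropyl on a nitrogen on an aromatic ring.

The closest measured precedent is a number 1.50 log units lower from compound 2 to compound 3 (beyond the scatter), where 1-carboxypropyl replaces 1-carbamoylpentyl at the same place. Read backwards, it points upward for a carbamoyl-bearing group. a number 1.40 log units higher from compound 1 to compound 2 (beyond the scatter) is of similar size and points the same way. For the measured compounds named here, neither step can be carried over whole, since 1-carbamoylpentyl is not the group entering here and no measured compound carries 1-carbamoyl-2-methoxyethyl. A rise is therefore expected, but a smaller one than those two steps. The expected size is a number 0.70 log units higher from compound 3 to compound 4 (beyond the scatter). For compound 4 the estimated value is 2.8, with an expected range of 2.3 to 3.3.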

Compound 4, distribution coefficient: 2.8
For compound 4 middle estimate and measured number coincide at the digits printed, and the stated range covers the measured number.
By their numbers in this assay, from the lowest: compounds 3 and 1 (each within the scatter of the next); then compound 4; then compound 2.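

In this assay, replacing 1-carboxypropyl with 1-carbamoyl-2-methoxyethyl on a nitrogen on an aromatic ring gives a number 0.70 log units higher from compound 3 to compound 4 (beyond the scatter), so the rise seen earlier with 1-carbamoylpentyl is also seen with a different carbamoyl-bearing group. For the compounds shown here, with the carbamoyl kept, methoxy in place of propyl on a saturated chain carbon gives a number 0.80 log units lower from compound 2 to compound 4 (beyond the scatter), the first reading of a change in this chain alone and one that is beyond the scatter. Against the carbon-linked acid, (1-carbamoyl-2-methoxyethyl)amino in place of 2-carboxypropyl on an aromatic carbon gives a number 0.60 log units higher from compound 1 to compound 4 (beyond the scatter), which places the methoxy amide clear of both acid-bearing compounds and still clear of compound 2.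

The step to compound 4 exchanges the acid for the carbamoyl and alters the chain at once, so the compounds shown do not divide it between those two changes; 1-carboxy-2-methoxyethyl and 1-carbamoylpropyl at this nitrogen would each bear on that division. No measurement to hand explains any of these steps.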